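A few compounds are considered here, and "the series" means these few. Any claim that something is new, unique, unknown or untested is made for them only; others in the source may bear on it.

Of the compounds shown here, two built on a shared core have been measured in a functional assay on HOS-TE85 cells (Homo sapiens) for inhibition, read by CCK-8 assay, with a stated time of 72 h; a lower number here means a stronger inhibitor, a higher number a weaker inhibitor. Compound 1 `CC1SC(c2cccc(C(=O)NCCCCc3ccc(Cl)cc3)c2)N(c2cccc(C3CC3)c2)C1=O` gives 932 nM in this assay, while compound 2 `C#Cc1cccc(N2C(=O)CSC2c2cccc(C(=O)NCCCCc3ccccc3)c2)c1` gives 149 nM. Of these two numbers, compound 2 stands lowest, and its gap to compound 1 lies beyond the scatter of repeated measurements. Compound 3 `Cc1cccc(N2C(=O)CSC2c2cccc(C(=O)NCCCCc3ccccc3)c2)c1` has not yet been measured. Within the data shown here, it differs from compound 2 in a single place: methyl in place of ethynyl on an aromatic carbon No pair of measured compounds shows this particular change, so its effect cannot be read from any measured step. In this assay the step is expected to be small, most likely toward a somewhat higher number, and it may well remain within the scatter. The estimated step is a 1.7-fold higher number from compound 2 to compound 3 (0.22 log units; within the scatter). Compound 3 is accordingly estimated at 250 nM, within a range from 100 nM to 650 nM.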

Compound 3, half-maximal inhibitory concentration in the HOS-TE85 assay: 93.2 nM
For compound 3 the middle estimate is 2.7-fold (0.43 log units) above the measured one; the whole stated range lies above it.
By their numbers in the HOS-TE85 assay, from the lowest: compounds 3 and 2 (each within the scatter of the next); then compound 1.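

Among these compounds, putting methyl in place of ethynyl on an aromatic carbon gives, in the HOS-TE85 assay, a 1.6-fold lower number from compound 2 to compound 3 (0.20 log units; within the scatter), so this pair shows that the two groups are not told apart at this position, something the earlier compounds could not show. In a physicochemical assay for solubility, read by turbidimetry, measured as kinetic solubility, at pH 6.8 (a higher number here means a more soluble compound, a lower number a less soluble compound), compound 2 gives 10000 nM and compound 3 gives 10000 nM, so the change leaves this number the same as well. Nothing shown here offers a reason for either result.

Among the compounds shown here, what an amine, a carboxylic acid or a methoxy group would do at this position stays open, as only two small carbon groups can be compared there. Compound 1 carries cyclopropyl instead, but it differs from the others in more than one place, so the effect of that group cannot be separated.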